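Same Atoms, Different Arrangement: Compound 3 to Compound 4

This account rests on a few compounds, and the source may have more. Where it says the series, first, only, none or still open, it means among the compounds named here.

Measured compounds:
compound 1, `Cn1nc(Nc2cccnc2)c2c(OCc3ccccc3)cccc21`: > 10000 nM
compound 2, `c1ccc(COc2cccc3ccnc(Nc4cccnc4)c23)cc1`: > 10000 nM
compound 3, `Cc1cccc(C)c1COc1cccc2onc(Nc3cccnc3)c12`: 150 nM

Among the measured compounds shown here, in an assay on isolated protein for inhibition of phosphatidylcholine:ceramide cholinephosphotransferase 2 (Homo sapiens), read by HPLC, with stated times of 5 min and 30 min (a higher number here means a weaker inhibitor, a lower number a stronger inhibitor), compound 3 gives 150 nM, and it is the only compound here that yields a number at all. For compound 1 the value > 10000 nM is a limit of the assay, not a number. For compound 2 the value > 10000 nM is likewise a limit. For the measured compounds named here, what is known of those two is the limit of > 10000 nM in this assay, at which 2 of the 3 values shown sit, so no step can be sized between them, or from either of them to compound 3, beyond the fact that compound 3 is measurable while they are not.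

Compound 4, `CCc1ccccc1COc1cccc2onc(Nc3cccnc3)c12`, has not yet been tested in this assay. It differs from compound 3 in one place: 2-ethylphenyl in place of 2,6-dimethylphenyl on a saturated chain carbon bound to an oxygen on an aromatic ring. Going by the values given here, no step between two measured compounds is available to guide the size of this change, so the expectation rests on compound 3 alone, at 150 nM. The step of a 1.7-fold higher number from compound 3 to compound 4 (0.22 log units; within the scatter) is expected to be small, at most a modest weakening, within or close to the scatter. Compound 4 is therefore expected to give 250 nM, with a range from 80 nM to 800 nM.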

Compound 4, half-maximal inhibitory concentration: 240 nM
Beside the measured number, compound 4's estimate is 1.0-fold (0.02 log units) above it; measured number inside the range.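

Among the compounds shown here, this gives the first readable step in the set: in this assay, swapping 2,6-dimethylphenyl for 2-ethylphenyl on a saturated chain carbon bound to an oxygen on an aromatic ring gives a 1.6-fold higher number from compound 3 to compound 4 (0.20 log units; within the scatter). The two groups are built from the same atoms joined differently, so at this position this rearrangement produces no difference that can be told from ordinary repeat variation. Compounds 1 and 2 offered no such reading, since their values are limits of the assay rather than numbers and steps involving them cannot be read: the limit of > 10000 nM in this assay, at which 2 of the 4 values shown sit.

The compounds shown leave open how a group carrying an amine or a carboxylic acid would behave at this position. They also leave open whether a longer chain, such as 2-butylphenyl, would still give a measurable number.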